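A few compounds are considered here, and "the series" means these few. Any claim that something is new, unique, unknown or untested is made for them only; others in the source may bear on it.

Measured compounds:
- compound 1, `Brc1ccc(OCCOc2nc3ccccc3s2)c(Br)c1`: 68.6%
- compound 2, `Brc1ccc(OCCOc2nc3ccccc3s2)cc1`: 68.6%
- compound 3, `O=[N+]([O-])c1ccc(COc2nc3ccccc3s2)cc1`: 97%

In a functional assay on the whole organism with Mus musculus as the target, in the writhing test, at a dose of 100 mg/kg by the intraperitoneal route (on this read-out lower numbers stand for less inhibition and higher numbers for more inhibition at the one dose given (going by the name of the read-out)), compound 2 gives 68.6%, level with compound 1 at the digits shown, the two together the lowest numbers of the three. Compound 3 gives 97%, a higher number, beyond the scatter. Within the data shown here, the only measured step, no change at the digits printed from compound 1 to compound 2 (within the scatter), removes a bromo from the aromatic carbon and leaves the read-out unchanged within the scatter.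

Compound 4, `Clc1ccc(OCCOc2nc3ccccc3s2)cc1`, differs from compound 2 by chloro in place of bromo on an aromatic carbon. The step from compound 1 to compound 2 is the one that bears on it: if losing the bromo altogether changed nothing, exchanging it for chloro is not expected to move the number beyond the scatter either. The expected step is a number 0.6 percentage points lower from compound 2 to compound 4 (within the scatter). Compound 4 is therefore estimated at 68%, within a range from 54% to 82%.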

Compound 4, a percentage reported as inhibition, in the whole organism at one dose (the size of the read-out at that dose, not a potency): 68.6%
For compound 4 the middle estimate is 0.6 percentage points below the measured one, within the range that was stated.
By their numbers in this assay, from the lowest: compounds 1, 2 and 4 (each within the scatter of the next); then compound 3.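

In this assay, chloro in place of bromo gives no change at the digits printed from compound 2 to compound 4 (within the scatter), so the two halogens cannot be told apart at this place, on an aromatic carbon para to a large group. Among these compounds, the earlier step removed a bromo from a different aromatic carbon, so this is the first reading at this place. Nothing on hand accounts for the result.

Open: whether an amine or a carboxylic acid at this place would move the number. Compound 3 differs from these compounds in more than one place, so the part of the structure behind its higher number remains unassigned.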